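From Methyl to Phenylsulfonyl on the Ring Nitrogen

The compounds below may be only part of what the source reports. "The series", "measured", "known", "first", "only" and "open" are said of these compounds alone.

Compound 1 `N#Cc1c(-c2ccccc2)nc(SCc2nc3ccccc3[nH]2)nc1N1CCNCC1`: 4.38 nM
Compound 2 `CN1CCN(c2nc(SCc3nc4ccccc4[nH]3)nc(-c3ccccc3)c2C#N)CC1`: 2.4 nM

In a functional assay on K562 cells (Homo sapiens) for cytotoxicity, read by MTT assay, with a stated time of 3 days (on this read-out lower numbers stand for stronger inhibition and higher numbers for weaker inhibition), compound 2 gives 2.4 nM. That value lies within the usual scatter of compound 1 at 4.38 nM, so the two cannot be ranked. The next compound is compound 3 `N#Cc1c(-c2ccccc2)nc(SCc2nc3ccccc3[nH]2)nc1N1CCN(S(=O)(=O)c2ccccc2)CC1`, which carries phenylsulfonyl in place of methyl on an amine nitrogen in a ring.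

Among the compounds with values here, only one measured step touches this nitrogen, a 1.8-fold lower number from compound 1 to compound 2 (0.26 log units; within the scatter), where methyl replaces hydrogen. That step stays within the scatter, but it reaches no further than methyl. Within the data shown here, no measured compound has phenylsulfonyl here, so the data give only weak guidance for so much larger a change, and the expectation must stay broad. A modest move to a higher number in this assay is expected, though a result within the scatter would not be surprising. The estimated change is a 3.8-fold higher number from compound 2 to compound 3 (0.57 log units; beyond the scatter). For compound 3 the estimated value is 9 nM, with an expected range from 2 nM to 45 nM.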

Compound 3, half-maximal inhibitory concentration: 3 nM
Estimate against measurement, compound 3: 3.0-fold (0.48 log units) above, within the range that was stated.
By their numbers in this assay, from the lowest: compounds 2, 3 and 1 (each within the scatter of the next).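

In this assay, the step from methyl to phenylsulfonyl on the amine nitrogen gives a 1.3-fold higher number from compound 2 to compound 3 (0.10 log units; within the scatter), and the step from hydrogen to phenylsulfonyl gives a 1.5-fold lower number from compound 1 to compound 3 (0.16 log units; within the scatter). The earlier compounds shown here reached no further than methyl on this nitrogen; these steps extend the series to a substituent with a six-membered aromatic ring of carbon only and a sulfonyl link, and hydrogen, methyl and phenylsulfonyl all stand within the scatter of one another, so the three compounds cannot be ranked. Nothing measured among these compounds speaks to why the numbers stay so close.

The compounds shown cover only hydrogen, methyl and phenylsulfonyl on this nitrogen, so it remains open whether an acetyl group, a benzyl group or a longer alkyl chain there would also stay within the scatter. Within the data shown here, also open is whether a chain ending in a carboxylic acid or a primary amine on this nitrogen would give the first step beyond the scatter in this assay.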